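The source may hold more compounds than are shown below. What is called first, only, known or untested is meant among the compounds shown, and "the series" means these compounds.

Working notes on the series.

Compound 1 `Oc1ccc(-c2cc(-c3ccccc3F)cc(-c3ccc(O)cc3)n2)cc1` carries two 4-hydroxyphenyl groups on the shared core and a 2-fluorophenyl group. In a functional assay on HeLa cells (Homo sapiens) for inhibition (a higher number here means a weaker inhibitor, a lower number a stronger inhibitor), compound 1 reaches only the limit of the assay, > 50000 nM, so no number is known for it; this is recorded as the limit of > 50000 nM in this assay, at which 1 of the 2 values shown sits.

Going by the values given here, compound 2 `Oc1ccc(-c2cc(-c3ccc(C(F)(F)F)cc3)cc(-c3cccc(O)c3)n2)cc1` is the only member of the pair with a numerical reading: in this assay compound 2 gives 17300 nM. Among the compounds with values here, since the other value is a limit, no ordering of the two can be stated, and the two compounds differ in more than one place, so no single step between them is defined.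

Compound 3 `Oc1ccc(-c2cc(-c3ccc(C(F)(F)F)cc3)cc(-c3ccc(O)cc3)n2)cc1` is not yet measured. It is built from compound 2 by 4-hydroxyphenyl in place of 3-hydroxyphenyl on an aromatic carbon. After this change compound 3 carries the same pair of 4-hydroxyphenyl groups as compound 1, with the 4-(trifluoromethyl)phenyl group of compound 2 retained.

For compound 3 a modest loss toward weaker inhibition is expected, a 1.7-fold higher number from compound 2 to compound 3 (0.24 log units; within the scatter), given that compound 1 with its two 4-hydroxyphenyl groups sits at the limit > 50000 nM. The estimate for compound 3 in this assay is 30000 nM, with a range from 10000 nM to 100000 nM.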

Compound 3, half-maximal inhibitory concentration: > 50000 nM
Compound 3 ended at the assay's limit (the forecaster's own chance of this, stated with the estimate: 40%); middle value at least 1.6-fold (0.22 log units) from the limit.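

Going by these compounds alone, with the 4-(trifluoromethyl)phenyl group held fixed, 4-hydroxyphenyl in place of 3-hydroxyphenyl on the aromatic carbon next to the ring nitrogen gives an at least 2.8-fold higher number from compound 2 to compound 3 (0.46 log units; beyond the scatter) in this assay, the first single-place step that can be read. It shows that this position responds to where the hydroxyl group sits on the phenyl ring, and that of the two arrangements shown only the 3-hydroxyphenyl group gives a numerical reading. The step from compound 1 to compound 3, 4-(trifluoromethyl)phenyl in place of 2-fluorophenyl, cannot be read, and compound 3 stands with compound 1 at a limit of the assay rather than at a number: the limit of > 50000 nM in this assay, at which 2 of the 3 values shown sit.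

Going by these compounds, how far the true values of compound 1 and compound 3 lie from that limit remains open, as does whether 3-hydroxyphenyl would also give a numerical reading alongside the 2-fluorophenyl group. Also open, on these data alone, is what an aminophenyl group or a carboxylic acid on the phenyl ring at this position, next to the ring nitrogen, would give in this assay.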